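Removing the last methyl from the biaryl end of compound 3

The source may hold more compounds than are shown below. What is called first, only, known or untested is meant among the compounds shown, and "the series" means these compounds.

Of the compounds shown here, three with a shared core have been measured in a functional assay on CHO cells for agonist activity at Free fatty acid receptor 1 (Homo sapiens), read by FLIPR and calcium flux; a higher number here means that more compound is needed for the effect, a lower number that less compound is needed. Compound 1 `Cc1cccc(C)c1-c1cccc(COc2ccc(S(=O)(=O)CC(=O)O)cc2)c1` gives 66.1 nM; compound 2 `COc1cc(C)c(-c2cccc(COc3ccc(S(=O)(=O)CC(=O)O)cc3)c2)c(C)c1` gives 57.5 nM; compound 3 `Cc1ccccc1-c1cccc(COc2ccc(S(=O)(=O)CC(=O)O)cc2)c1` gives 46.8 nM. Compound 3 has the lowest of the three numbers, but the nearest, compound 2, sits only a 1.2-fold lower number from compound 2 to compound 3 (0.09 log units; within the scatter) away, and the furthest, compound 1, only a 1.4-fold lower number from compound 1 to compound 3 (0.15 log units; within the scatter), so the three values cannot be told apart in this assay.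

The next compound, compound 4 `O=C(O)CS(=O)(=O)c1ccc(OCc2cccc(-c3ccccc3)c2)cc1`, differs from compound 3 in one place: hydrogen in place of methyl on an aromatic carbon. The methyl that leaves sits ortho to a large group; read one bond further out, 2-methylphenyl becomes phenyl.

One measured step is of the same kind. From compound 1 to compound 3 a methyl on an aromatic carbon was also replaced by hydrogen, and that gave a 1.4-fold lower number from compound 1 to compound 3 (0.15 log units; within the scatter), a change inside the usual scatter. For the measured compounds named here, the other two steps, a 1.1-fold lower number from compound 1 to compound 2 (0.06 log units; within the scatter) and a 1.2-fold lower number from compound 2 to compound 3 (0.09 log units; within the scatter), also stayed within the scatter, so nothing measured so far argues for a large shift in this assay. The one remaining methyl may still matter, so a modest rise in the number is possible. Compound 4 is therefore expected to give 80 nM in this assay, in a range from 30 nM to 250 nM. That estimate corresponds to an expected step of a 1.7-fold higher number from compound 3 to compound 4 (0.23 log units; within the scatter).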

Compound 4, half-maximal effective concentration: 288 nM
Compound 4: middle estimate off by 3.6-fold (0.56 log units), on the low side; the whole stated range lies below it.
By their numbers in this assay, from the lowest: compounds 3, 2 and 1 (each within the scatter of the next); then compound 4.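

In this assay, taking away the last methyl on the ring gives a 6.2-fold higher number from compound 3 to compound 4 (0.79 log units; beyond the scatter), a step beyond the scatter, whereas the same swap of methyl for hydrogen on an aromatic carbon between compound 1 and compound 3 stayed within it. So the effect of this change depends on what else the ring carries: going from two methyls to one made no clear difference, but going from one to none did. The plain phenyl of compound 4 also stands apart from the more substituted rings, with a 5.0-fold higher number from compound 2 to compound 4 (0.70 log units; beyond the scatter) for the change from 4-methoxy-2,6-dimethylphenyl and a 4.4-fold higher number from compound 1 to compound 4 (0.64 log units; beyond the scatter) for the change from 2,6-dimethylphenyl, and nothing shown here explains why the last methyl counts for so much.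

Whether a methyl is specifically needed at this place remains open, since the compounds shown do not include another small group there, such as a chlorine atom or an ethyl group. It is also unknown whether the methyl would matter as much if the carboxylic acid at the other end of the molecule were replaced by an amide.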